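This account rests on a few compounds, and the source may have more. Where it says the series, first, only, none or still open, it means among the compounds named here.

Measured in a toxicity assay on THP-1 cells (Homo sapiens) for cytotoxicity, read by luminescence and CellTiter-Glo, with a stated time of 72 h; on this read-out lower numbers stand for higher toxicity in this test and higher numbers for lower toxicity in this test:
compound 1 `Cc1ccc(-c2ccnc(Nc3ccc(N4CCN(C)CC4)c(C(F)(F)F)c3)n2)cc1`: 4940 nM
compound 2 `CN1CCN(c2ccc(Nc3nccc(-c4ccnc(Cl)c4)n3)cc2C(F)(F)F)CC1`: 1140 nM

Of the two measured compounds, compound 2 has the lower number, 1140 nM, and the gap to compound 1 lies beyond the scatter. Compound 3 `CN1CCN(c2ccc(Nc3nccc(-c4cccc([N+](=O)[O-])c4)n3)cc2C(F)(F)F)CC1` differs from compound 2 in one place: 3-nitrophenyl in place of 2-chloropyridin-4-yl on an aromatic carbon. Among the measured compounds shown here, only one measured step bears on this change. It is a 4.3-fold lower number from compound 1 to compound 2 (0.64 log units; beyond the scatter), a modest step in which 2-chloropyridin-4-yl replaced 4-methylphenyl. For the measured compounds named here, compound 3 again has a six-membered aromatic ring of carbon only at this place, as compound 1 does, but no measured compound carries 3-nitrophenyl. A single step gives only weak guidance, so a partial return towards compound 1, at 4940 nM, is expected rather than a full one. The expected change is a 1.8-fold higher number from compound 2 to compound 3 (0.27 log units; within the scatter), a small step to a higher number. For compound 3 the estimated value is 2100 nM, with an expected range from 750 nM to 6000 nM.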

Compound 3, half-maximal cytotoxic concentration in the THP-1 assay: 3890 nM
Beside the measured number, compound 3's estimate is 1.9-fold (0.27 log units) below it; low and high end bracket the measured number.
By their numbers in the THP-1 assay, from the lowest: compound 2; then compounds 3 and 1 (each within the scatter of the next).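

In the THP-1 assay, the exchange of 2-chloropyridin-4-yl for 3-nitrophenyl gives a 3.4-fold higher number from compound 2 to compound 3 (0.53 log units; beyond the scatter), and the exchange of 4-methylphenyl for 3-nitrophenyl gives a 1.3-fold lower number from compound 1 to compound 3 (0.10 log units; within the scatter), so the two groups with a six-membered aromatic ring of carbon only are not told apart at this place, while 2-chloropyridin-4-yl alone stands apart, with compound 2 at 1140 nM as the lowest number. The exchange of 2-chloropyridin-4-yl for 3-nitrophenyl also leaves the two compounds within the scatter of each other in a physicochemical assay for lipophilicity, read by LC-MS, in phosphate buffer, measured as octanol-water partition, at pH 7.4, tested at 66.7 uM (on this read-out higher numbers stand for higher lipophilicity and lower numbers for lower lipophilicity), where compound 2 gives 4.3 and compound 3 gives 4.5, at a number 0.20 log units higher from compound 2 to compound 3 (within the scatter). Nothing available explains why the ring with one hetero atom differs from the two carbon-only rings in this test.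

It stays open whether the ring nitrogen or the chlorine of 2-chloropyridin-4-yl goes with the lower number in the THP-1 assay, as the compounds shown change both together, and a plain pyridine ring or a chlorophenyl group at this place would separate them. With only three groups shown here, it is also open how the number would respond to an amine or a carboxylic acid on the ring at this place.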